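Iodo for methyl on the aryl ring of compound 3

The compounds below may be only part of what the source reports. "The series", "measured", "known", "first", "only" and "open" are said of these compounds alone.

In a functional assay on the whole organism (integument) for inhibition, with Chilo suppressalis as the target, read by scintillation counting, with a stated time of 72 h (on this read-out lower numbers stand for stronger inhibition and higher numbers for weaker inhibition), compound 3 `COc1cccc(OC)c1C(=O)Nc1nnc(-c2ccc(C)cc2)s1` gives 1230 nM, the higher of the two numbers shown. Compound 2 `Cc1ccccc1C(=O)Nc1nnc(-c2ccc(Cl)cc2)s1` gives 158 nM. Compound 1 `O=C(Nc1nnc(-c2ccc(Cl)cc2)s1)c1ccccc1Cl` reaches only the limit > 5010 nM of this assay. Compound 4 `COc1cccc(OC)c1C(=O)Nc1nnc(-c2ccc(I)cc2)s1` differs from compound 3 by iodo in place of methyl on an aromatic carbon. Going by the values given here, the only measured step, an at least 31-fold lower number from compound 1 to compound 2 (1.50 log units; beyond the scatter), concerns the reverse exchange, a chloro giving way to methyl, and sits elsewhere in the shared core; read backwards it points toward a higher number on return to a halogen, but with chloro rather than iodo its size cannot be carried over. A moderate rise in this assay is therefore expected, a 2.0-fold higher number from compound 3 to compound 4 (0.31 log units; beyond the scatter), with some chance of a limit. Compound 4 is estimated at 2500 nM, between 800 nM and 8000 nM.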

Compound 4, half-maximal inhibitory concentration: 89.1 nM
Estimate against measurement, compound 4: 28-fold (1.45 log units) above, and the stated range ends above it.
By their numbers in this assay, from the lowest: compounds 4 and 2 (each within the scatter of the next); then compound 3. At a limit, above all of these: compound 1.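

The change from 4-methylphenyl to 4-iodophenyl gives a 14-fold lower number from compound 3 to compound 4 (1.14 log units; beyond the scatter) in this assay, so at this place, on an aromatic carbon para to a large group, a halogen goes with the lower number. Across the shared core, halogen is therefore not tied to a higher number: at another place, methyl in place of chloro gave an at least 31-fold lower number from compound 1 to compound 2 (1.50 log units; beyond the scatter), the opposite direction. No measured property bears on this step.

Going by these compounds, it remains open whether fluoro, bromo, an amine or a carboxylic acid at this place would follow iodo or methyl.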